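A chloro-to-amino exchange under cytotoxicity testing

The source may hold more compounds than are shown below. What is called first, only, known or untested is meant among the compounds shown, and "the series" means these compounds.

Compound 1 `Nc1ccccc1NC(=O)c1ccc(NC(=S)NCc2cccc(Cl)c2)cc1` gives 5900 nM
Compound 2 `Nc1ccccc1NC(=O)c1ccc(NC(=O)NCc2ccc(Cl)nc2)cc1` gives 5200 nM

Both numbers come from a functional assay on HCT-116 cells (Homo sapiens) for cytotoxicity, read by MTT assay, with a stated time of 72 h (on this read-out higher numbers stand for weaker inhibition and lower numbers for stronger inhibition), and they sit close together. Compound 2 at 5200 nM lies within the scatter of compound 1 at 5900 nM on this read-out, so the two cannot be told apart.

The next compound, compound 3 `Nc1ccc(CNC(=O)Nc2ccc(C(=O)Nc3ccccc3N)cc2)cn1`, departs from compound 2 in one place, (amino in place of chloro on an aromatic carbon), with amino in place of chloro on an aromatic carbon, next to the ring nitrogen of a six-membered aromatic ring with 1 nitrogen.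

Among the measured compounds shown here, no measured pair shows what this exchange does in this assay, so the data set no direction for it. The expectation therefore stays close to compound 2 at 5200 nM as its starting point. The expected change a 1.2-fold lower number from compound 2 to compound 3 (0.06 log units; within the scatter) is no larger than the scatter, in neither direction. For compound 3 the estimate is 4500 nM and the expected range runs from 1500 nM to 13000 nM on this read-out.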

Compound 3, half-maximal inhibitory concentration: 7300 nM
The estimate for compound 3 lay 1.6-fold (0.21 log units) below the measured number; low and high end bracket the measured number.
By their numbers in this assay, from the lowest: compounds 2, 1 and 3 (each within the scatter of the next).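

In this assay, the exchange of chloro for amino on this aromatic carbon, next to the ring nitrogen and para to a large group, gives a 1.4-fold higher number from compound 2 to compound 3 (0.15 log units; within the scatter), so this first measured pair for the change cannot separate the 6-chloropyridin-3-yl and 6-aminopyridin-3-yl forms. At this position, then, the read-out registers no difference between the two groups, even though amino carries a hydrogen-bond donor and a hydrogen-bond acceptor that are absent from the chloro group. No independent measurement is available here that would help to interpret this result.

The compounds shown leave open whether a larger replacement at the same carbon, such as a methoxy group, a dimethylamino group or a carboxylic acid, would also stay within the scatter of compound 2 or would move the number beyond it. They also leave open whether the exchange of chloro for amino would give a similar result on another ring or at another ring position, since this single pair speaks only for this place on the shared core.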